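The source may report more compounds than this note shows. Statements on the series, on what has been measured and on what is new or still open speak of the compounds shown alone.

In a functional assay on the whole organism for inhibition, with Mythimna separata as the target, with a stated time of 5 days (on this read-out lower numbers stand for an effect already at smaller amounts and higher numbers for an effect only at larger amounts of compound), compound 3 `CC(C)(C)n1ncc(OCc2nnc(-c3ccccc3)o2)c(Cl)c1=O` gives 12.2 ug/mL and stands highest of the two numbers shown, although compound 1 `CC(C)(C)n1ncc(OCc2nnc(-c3cccc(F)c3)o2)c(Cl)c1=O` gives 7.1 ug/mL and the step of a 1.7-fold higher number from compound 1 to compound 3 (0.24 log units; within the scatter) stays within the scatter. Compound 2 `CC(C)(C)n1ncc(OCc2nnc(-c3cccs3)o2)c(Cl)c1=O` reaches only the limit of > 300 ug/mL in this assay. Compound 4 `COc1ccc(-c2nnc(COc3cnn(C(C)(C)C)c(=O)c3Cl)o2)cc1` differs from compound 3 by methoxy in place of hydrogen on an aromatic carbon. Among the measured steps, only the swap of one small group on the carbon-only ring, a 1.7-fold higher number from compound 1 to compound 3 (0.24 log units; within the scatter), resembles this change, and it was small; the ring exchanges an at least 42-fold higher number from compound 1 to compound 2 (1.62 log units; beyond the scatter) and an at least 24-fold lower number from compound 2 to compound 3 (1.39 log units; beyond the scatter) were large but are of another kind. The expected step of a 1.1-fold lower number from compound 3 to compound 4 (0.04 log units; within the scatter) in this assay is therefore small, with no set direction. Compound 4 is estimated at 11 ug/mL, within 4 ug/mL to 35 ug/mL.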

Compound 4, half-maximal effective concentration: 17.7 ug/mL
Estimate against measurement, compound 4: 1.6-fold (0.21 log units) below; measured number inside the range.
By their numbers in this assay, from the lowest: compounds 1, 3 and 4 (each within the scatter of the next, the first and the last beyond it). At a limit, above all of these: compound 2.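

In this assay, methoxy on the six-membered aromatic ring of carbon only, para to a large group, leaves the number within the scatter: a 1.5-fold higher number from compound 3 to compound 4 (0.16 log units; within the scatter). The two substituted phenyl rings do separate, however, in a 2.5-fold higher number from compound 1 to compound 4 (0.40 log units; beyond the scatter), and the 4-methoxyphenyl ring keeps the large gain over thiophen-2-yl, an at least 16-fold lower number from compound 2 to compound 4 (1.22 log units; beyond the scatter). Compound 2 remains a limit: the limit of > 300 ug/mL in this assay, at which 1 of the 4 values shown sits.

The compounds shown leave open whether a 4-fluorophenyl or 3-methoxyphenyl ring would follow the same order, so group and position cannot be told apart. From the compounds shown here alone, how an amine or a carboxylic acid would behave at this place also stays open.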